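Benzofuran in Place of Thiophene on a Nucleoside Core

The compounds below may be only part of what the source reports. "The series", "measured", "known", "first", "only" and "open" are said of these compounds alone.

Compound 1 `Cc1nc(N)c2c(-c3cccs3)cn([C@@H]3O[C@H](CO)[C@@H](O)[C@H]3O)c2n1` and compound 2 `Cc1nc(N)c2c(-c3cc4ccccc4o3)cn([C@@H]3O[C@H](CO)[C@@H](O)[C@H]3O)c2n1` share one core and differ in a single group. In a functional assay on HCT-116 cells (Homo sapiens), read by MTT assay, with a stated time of 72 h (on this read-out higher numbers stand for weaker inhibition and lower numbers for stronger inhibition), compound 1 reaches only a limit of the measurement, > 20000 nM. In this assay compound 2 likewise stops at a limit, > 20000 nM. The change between them is 1-benzofuran-2-yl in place of thiophen-2-yl on an aromatic carbon, and the step it made is a step that the two limits leave unreadable from compound 1 to compound 2. Compound 3 `CN(C)c1ncnc2c1c(-c1cccs1)cn2[C@@H]1O[C@H](CO)[C@@H](O)[C@H]1O` carries another core; the difference between the two cores is not broken down here. In this assay compound 3 also gives only a limit, > 20000 nM. Compound 4 `CN(C)c1ncnc2c1c(-c1cc3ccccc3o1)cn2[C@@H]1O[C@H](CO)[C@@H](O)[C@H]1O` has not been measured and differs from compound 3 by 1-benzofuran-2-yl in place of thiophen-2-yl on an aromatic carbon, the same change, at the same place, as that between compound 1 and compound 2. Because the limit of > 20000 nM in this assay, at which 3 of the 3 values shown sit, holds for every measured value, this change has shown nothing readable, and the step expected here is a step that the limit leaves unreadable from compound 3 to compound 4. Compound 4 is therefore expected to stay at the limit as well, near 30000 nM, within a range from 15000 nM to 100000 nM.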

Compound 4, half-maximal inhibitory concentration: > 20000 nM
Compound 4 was reported as a limit; the forecaster's own chance of this, stated with the estimate: 85%; the middle value lies beyond the limit too.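

The step from compound 3 to compound 4 cannot be read, because both values are limits of the measurement rather than numbers: the limit of > 20000 nM in this assay, at which 4 of the 4 values shown sit. The compounds shown leave open whether thiophen-2-yl and 1-benzofuran-2-yl differ at all in their effect on these cells, and whether the two cores do.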